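The source may hold more compounds than are shown below. What is called first, only, known or untested is meant among the compounds shown, and "the series" means these compounds.

Among the measured compounds shown here, compound 1 `O=C1/C(=C\c2ccc(O)cc2)c2ccccc2N1c1c(Cl)cccc1Cl` is the only compound in this set with a single number in a functional assay on B16-F10 cells (Homo sapiens) for cytotoxicity against B16-F10 (Mus musculus), read by MTT assay, with a stated time of 72 h; a higher number here means that more compound is needed for the effect, a lower number that less compound is needed: compound 1 gives 33 ug/mL. The other two entries stand apart from it. Compound 3 `COc1ccc(/C=C2\C(=O)N(c3c(Cl)cccc3Cl)c3ccccc32)cc1` reaches only a limit of the assay, giving > 100 ug/mL. Compound 2 `Cc1ccc2nc(Cl)c(/C=C3\C(=O)N(c4c(Cl)cccc4Cl)c4ccccc43)cc2c1` has no reported result in this assay, shown as "not determined" (no result reported).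

For the measured compounds named here, the one measured step that can be followed is the move an at least 3.0-fold higher number from compound 1 to compound 3 (0.48 log units; beyond the scatter), which takes compound 1 past the limit (the limit of > 100 ug/mL in this assay, at which 1 of the 3 values shown sits). It removes the hydrogen from the oxygen on the aromatic ring and with it the donor that compound 1 carries there.

Compound 4 `O=C1/C(=C\c2ccc(Cl)cc2)c2ccccc2N1c1c(Cl)cccc1Cl` differs from compound 1 by chloro in place of hydroxy on an aromatic carbon. This change also removes the hydroxy, and with it the donor and acceptor, so the step from compound 1 to compound 3 is the closest guide. That step was at least modest and in the direction of a higher number, and a step of similar size and direction is therefore expected here, with a real chance that compound 4 also lands beyond the limit. The estimated step is a 2.4-fold higher number from compound 1 to compound 4 (0.38 log units; beyond the scatter). Compound 4 is thus expected to give about 80 ug/mL, within a range from 30 ug/mL to 160 ug/mL.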

Compound 4, concentration for half-maximal effect: > 100 ug/mL
Compound 4: a limit, no number; the forecaster's own chance of this, stated with the estimate: 45%; middle value at least 1.2-fold (0.09 log units) from the limit.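

In this assay the change from 4-hydroxyphenyl to 4-chlorophenyl appears as an at least 3.0-fold higher number from compound 1 to compound 4 (0.48 log units; beyond the scatter) and so lies beyond the scatter. Together with the earlier step, this shows that two different replacements at this place on the ring, a methyl on the oxygen and a chloro in place of the hydroxy, both leave the single number of compound 1 behind. As far as these compounds go, compound 4 joins compound 3 at a limit of the assay and not at a number, so the size of the loss remains unknown for either change, and the step between these two compounds cannot be read: the limit of > 100 ug/mL in this assay, at which 2 of the 4 values shown sit.

The compounds shown leave open how far compound 3 and compound 4 lie past that limit, and whether the chloro and the methoxy differ at all. They also leave open whether an amine, a carboxylic acid or a fluoro at this place on the ring would give a number close to that of compound 1, or whether the hydroxy moved elsewhere on the ring would do so.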